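This account rests on a few compounds, and the source may have more. Where it says the series, first, only, none or still open, it means among the compounds named here.

For the measured compounds named here, in a functional assay on the whole organism (Hindlimb, strain albino) with Mus musculus as the target, in the maximal electroshock model, with a stated time of 0.5 h (on this read-out higher numbers stand for an effect only at larger amounts of compound and lower numbers for an effect already at smaller amounts), compound 2 `CC(=O)N1N=C(Nc2nc3ccc(C)cc3s2)CC1OC1=CC=C1` gives 160 umol/kg, the higher of the two numbers so far, and compound 1 `CC(=O)N1N=C(Nc2nc3ccc(C)cc3s2)CC1c1ccc(O)cc1` gives 50.2 umol/kg. Compound 3 `CC(=O)N1N=C(Nc2nc3ccc(C)cc3s2)CC1c1ccc(Cl)cc1` differs from compound 2 as follows: a group of 7 heavy atoms (6 carbon, 1 chlorine; one six-membered aromatic ring of carbon only) in place of a group of 5 heavy atoms (4 carbon, 1 oxygen; one four-membered non-aromatic ring of carbon only), on a saturated ring carbon, which brings back a six-membered aromatic ring of carbon only, as in compound 1. Going by the values given here, the one measured step bearing on this is a 3.2-fold higher number from compound 1 to compound 2 (0.50 log units; beyond the scatter). Read in reverse, it points to a modest step towards a lower number in this assay, though the effect of chlorine in place of the hydroxyl is untested. The expected change is a 3.6-fold lower number from compound 2 to compound 3 (0.55 log units; beyond the scatter). Compound 3 is estimated at 45 umol/kg, with an expected range of 18 umol/kg to 110 umol/kg.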

Compound 3, dose for half-maximal effect: 25.5 umol/kg
Compound 3: the middle estimate sits 1.8-fold (0.25 log units) above what was measured; the range from low to high includes it.
By their numbers in this assay, from the lowest: compounds 3 and 1 (each within the scatter of the next); then compound 2.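

In this assay, 4-chlorophenyl in place of the four-membered carbon ring group on the saturated ring carbon gives a 6.3-fold lower number from compound 2 to compound 3 (0.80 log units; beyond the scatter). Chloro in place of hydroxy on an aromatic carbon gives a 2.0-fold lower number from compound 1 to compound 3 (0.29 log units; within the scatter), so this pair is not separated, and both compounds with the six-membered aromatic ring give lower numbers than compound 2. No evidence on the cause of these steps is at hand.

On these data alone, an amine or a methoxy group on the aromatic ring remains open. So does a longer chain on the saturated ring carbon.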